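The source may report more compounds than this note shows. Statements on the series, on what has been measured and on what is new or still open speak of the compounds shown alone.

In a functional assay on the whole organism (strain Wistar) for inhibition, with Rattus norvegicus as the target, read by paw edema, with stated times of 1 h and 5 h, at a dose of 20 mg/kg by the oral route (on this read-out higher numbers stand for more inhibition at the one dose given (going by the name of the read-out) and lower numbers for less inhibition), three close relatives have already been measured. Compound 1 `NS(=O)(=O)c1ccc2nc(N3N=C(c4ccc(Br)cc4)CC3c3ccc(Cl)cc3)sc2c1` gives 14%, compound 2 `NS(=O)(=O)c1ccc2nc(N3N=C(c4ccc(Br)cc4)CC3c3ccc(F)cc3)sc2c1` gives 14%, and compound 3 `COc1ccc(C2CC(c3ccc(Br)cc3)=NN2c2nc3ccc(S(N)(=O)=O)cc3s2)cc1` gives 14%. The three differ in a single group on one six-membered aromatic ring: no change at the digits printed from compound 1 to compound 2 (within the scatter) with fluoro in place of chloro on an aromatic carbon, no change at the digits printed from compound 1 to compound 3 (within the scatter) with methoxy in place of chloro on an aromatic carbon, and no change at the digits printed from compound 2 to compound 3 (within the scatter) with methoxy in place of fluoro on an aromatic carbon. Compound 3 therefore stands level with compound 1 and compound 2.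

Compound 4 `COc1ccc(C2CC(c3ccc(Cl)cc3)=NN2c2nc3ccc(S(N)(=O)=O)cc3s2)cc1` has not been measured. It differs from compound 3 by chloro in place of bromo on an aromatic carbon. This change sits on the ring that the measured steps leave untouched, so none of them bears directly on it; what they show is that small swaps of one group on a six-membered aromatic ring left the read-out unmoved. The step is expected to be no change at the digits printed from compound 3 to compound 4 (within the scatter), nothing beyond the scatter. Compound 4 is estimated to give 14%, between 5% and 25%.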

Compound 4, a percentage reported as inhibition, in the whole organism at one dose (the size of the read-out at that dose, not a potency): 67.7%
Beside the measured number, compound 4's estimate is 53.7 percentage points below it; measured number outside the range, above it.
By their numbers in this assay, from the lowest: compounds 1, 2 and 3 (each within the scatter of the next); then compound 4.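

In this assay chloro in place of bromo gives a number 53.7 percentage points higher from compound 3 to compound 4 (beyond the scatter) on the 4-bromophenyl ring, while the swaps on the other aromatic ring among compounds 1, 2 and 3 stayed within the scatter. The flat readings of those three compounds therefore did not hold for every small swap: here, exchanging one halogen for another, with no change in ring, hydrogen-bond donors, acceptors or net charge, produces a large step. Nothing available explains why this exchange has such a large effect.

Chloro at this place appears only alongside methoxy on the other ring, so whether the high reading depends on that partner remains open. From the compounds shown here alone, how a methyl, a nitrile or an amine at this place would read also remains unknown.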